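This account rests on a few compounds, and the source may have more. Where it says the series, first, only, none or still open, it means among the compounds named here.

Compound 2 `COc1cc(OC)c2c(=O)c(OCC(=O)N/N=C/c3ccccc3F)c(-c3cc(OC)c(OC)c(OC)c3)oc2c1` sets the lowest number of the three in a functional assay on MGC-803 cells (Homo sapiens) for cytotoxicity, read by MTT assay, with a stated time of 38 h (on this read-out higher numbers stand for weaker inhibition and lower numbers for stronger inhibition), where compound 2 gives 2780 nM. Compound 1 `COc1cc(OC)c2c(=O)c(OCCCCN3CCCC3)c(-c3cc(OC)c(OC)c(OC)c3)oc2c1` gives 18600 nM, and compound 3 `COc1cc(OC)c2c(=O)c(OCCCCN3CCCCC3)c(-c3cc(OC)c(OC)c(OC)c3)oc2c1` gives 26800 nM; the two differ by a 1.4-fold higher number from compound 1 to compound 3 (0.16 log units; within the scatter). Compound 4 `COc1cc(OC)c2c(=O)c(OCCCN3CCCC3)c(-c3cc(OC)c(OC)c(OC)c3)oc2c1` differs from compound 2 as follows: a group of 7 heavy atoms (6 carbon, 1 nitrogen; one five-membered non-aromatic ring with 1 hetero atom) in place of a group of 12 heavy atoms (8 carbon, 2 nitrogen, 1 oxygen, 1 fluorine; one six-membered aromatic ring of carbon only), on a saturated chain carbon bound to an oxygen on an aromatic ring. Going by the values given here, two measured steps bear on this change. Replacing the pyrrolidinyl-chain group of compound 1 with the acylhydrazone group moved a 6.7-fold lower number from compound 1 to compound 2 (0.83 log units; beyond the scatter); the reverse exchange toward the piperidinyl chain moved a 9.6-fold higher number from compound 2 to compound 3 (0.98 log units; beyond the scatter). Nothing measured covers the shorter chain of compound 4, so the expectation rests on those two steps. Compound 4 is therefore expected to show a step of a 6.8-fold higher number from compound 2 to compound 4 (0.83 log units; beyond the scatter), a higher number. Compound 4 is estimated at 19000 nM, with a range of 7000 nM to 50000 nM.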

Compound 4, half-maximal inhibitory concentration: 32100 nM
For compound 4 the middle estimate is 1.7-fold (0.23 log units) below the measured one; measured number inside the range.
By their numbers in this assay, from the lowest: compound 2; then compounds 1, 3 and 4 (each within the scatter of the next).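

In this assay, 2-(pyrrolidin-1-yl)ethyl in place of the group of compound 2 gives a 12-fold higher number from compound 2 to compound 4 (1.06 log units; beyond the scatter), so the gap to compound 2 also holds for this shorter amine chain. The chain change itself shows little: a 1.7-fold higher number from compound 1 to compound 4 (0.24 log units; within the scatter) and a 1.2-fold higher number from compound 3 to compound 4 (0.08 log units; within the scatter) both stay within the scatter, so compounds 1, 3 and 4 cannot be ordered. No supporting data explain the gap to compound 2. Open, going by these compounds, is which part of the group of compound 2 carries the gap, and whether a morpholine ring or a chloro in place of the fluoro would keep it.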